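Cytotoxicity notes: chloro substitution on the amine-linked heteroaryl

The source may hold more compounds than are shown below. What is called first, only, known or untested is meant among the compounds shown, and "the series" means these compounds.

The series is read in an ADME assay on PC-3 cells (Homo sapiens) for cytotoxicity, read by CCK-8 assay, with a stated time of 6 days; on this read-out lower numbers stand for stronger inhibition and higher numbers for weaker inhibition. Compound 1 `C[C@@H](Cn1ccc(-c2ccc(C#N)c(Cl)c2)n1)Nc1ncccn1` is the parent. In this assay compound 1 returns only a limit, > 30000 nM. Compound 2 `C[C@@H](Cn1ccc(-c2ccc(C#N)c(Cl)c2)n1)Nc1nccc(Cl)n1` carries the change (chloro in place of hydrogen on an aromatic carbon). In this assay compound 2 likewise returns only a limit, > 30000 nM. The step that the two limits leave unreadable from compound 1 to compound 2 therefore cannot be sized, because the limit of > 30000 nM in this assay, at which 2 of the 3 values shown sit, hides it.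

Compound 3 `C[C@@H](Cn1ccc(-c2ccc(C#N)c(Cl)c2)n1)Nc1ncnc2nc[nH]c12` differs from compound 1 by a group of 9 heavy atoms (5 carbon, 4 nitrogen; one five-membered aromatic ring with 2 hetero atoms, one six-membered aromatic ring with 2 hetero atoms) in place of a group of 6 heavy atoms (4 carbon, 2 nitrogen; one six-membered aromatic ring with 2 hetero atoms), on an amine nitrogen, and this is also how the core of compound 3 differs from the core of compound 1. In this assay, going by the values given here, compound 3 gives 14100 nM, the only number in the set. The steps of an at least 2.1-fold lower number from compound 1 to compound 3 (0.32 log units; beyond the scatter) and an at least 2.1-fold lower number from compound 2 to compound 3 (0.32 log units; beyond the scatter) are the only readable ones.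

Compound 4 `C[C@@H](Cn1ccc(-c2ccc(C#N)c(Cl)c2)n1)Nc1nc(Cl)nc2nc[nH]c12` is not yet measured. It carries chloro in place of hydrogen on an aromatic carbon. This is the same kind of change as chloro in place of hydrogen on an aromatic carbon but not the same: here the carbon sits between two ring nitrogen atoms, meta to a fused ring and para to a fused ring, within a fused system of two rings, whereas on compound 1 the carbon sits next to the ring nitrogen and opposite the ring nitrogen. Since the comparable step that the two limits leave unreadable from compound 1 to compound 2 is unreadable, the expectation for compound 4 rests on compound 3 alone and on the absence of any visible shift. Compound 4 is expected to give 14000 nM in this assay, between 6000 nM and 30000 nM, meaning an estimated step of a 1.0-fold lower number from compound 3 to compound 4 (0.00 log units; within the scatter).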

Compound 4, half-maximal inhibitory concentration: > 30000 nM
Compound 4: no number, only a limit; the forecaster's own chance of this, stated with the estimate: 30%; at least 2.1-fold (0.33 log units) between middle value and limit.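

In this assay, chloro in place of hydrogen on an aromatic carbon, here between two ring nitrogen atoms, gives an at least 2.1-fold higher number from compound 3 to compound 4 (0.32 log units; beyond the scatter), and since compound 4 returns only a limit, this fixes a smallest size for the step and not its true size. The matching step on the core of compound 1 and every other step that ends at this ceiling with a limit on both sides cannot be read, because the values disappear into the same limit: the limit of > 30000 nM in this assay, at which 3 of the 4 values shown sit. The change therefore has a readable effect on one core only, so the series shows that chloro-bearing compounds 2 and 4 both end at a limit, but it does not show that the change acts alike on the two cores, where it also sits in different surroundings.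

The compounds shown leave open whether another group on this same carbon, such as an amine or a methyl, would stay level with compound 3 at 14100 nM or also move away from it. They also leave open whether chloro on a different carbon of the core of compound 3 would give a readable number.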